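The source may hold more compounds than are shown below. What is called first, only, known or untested is meant among the compounds shown, and "the series" means these compounds.

Measured compounds:
- compound 1, `COc1ccc(C(=O)O)cc1OCCCCOc1ccc(C(=O)CC(C)C)c(O)c1C`: 737 nM
- compound 2, `CCCC(=O)c1ccc(OCCCCOc2cc(C(=O)O)ccc2OC)c(C)c1O`: 496 nM
- compound 3, `COc1ccc(C(=O)O)cc1OCCCCOc1ccc(C(=O)CC2CCCC2)c(O)c1C`: 1020 nM

These three share one core and differ only in the chain attached to the ketone carbonyl. In an assay on HEK293 cells for positive allosteric modulation of metabotropic glutamate receptor 3 (Rattus norvegicus), read by thallium flux, with a stated time of 2.5 min (a lower number here means that less compound is needed, a higher number that more compound is needed for the effect), compound 3 gives the highest of the three numbers. Its nearest neighbour is compound 1, since a 1.4-fold higher number from compound 1 to compound 3 (0.14 log units; within the scatter); the wider gap is to compound 2, since a 2.1-fold higher number from compound 2 to compound 3 (0.31 log units; beyond the scatter).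

Compound 4, `COc1ccc(C(=O)O)cc1OCCCCOc1ccc(C(=O)C(C)C)c(O)c1C`, is the next step from compound 3. The change is isopropyl in place of cyclopentylmethyl on a carbonyl carbon.

For the measured compounds named here, two measured steps bear on it. Swapping a ring for a branched chain on the carbon bound to the carbonyl carbon gave a 1.4-fold higher number from compound 1 to compound 3 (0.14 log units; within the scatter), which stayed within the scatter. Shortening the chain by one carbon gave a 1.5-fold lower number from compound 1 to compound 2 (0.17 log units; within the scatter), again within the scatter. Compound 4 combines a loss of the ring with a shorter chain, so the expected step in this assay is a 1.6-fold lower number from compound 3 to compound 4 (0.20 log units; within the scatter), a somewhat lower number but not clearly beyond the scatter. Compound 4 is therefore estimated at 650 nM, in the range 320 nM to 1300 nM.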

Compound 4, half-maximal effective concentration: 588 nM
Compound 4: middle estimate off by 1.1-fold (0.04 log units), on the high side; the range from low to high includes it.
By their numbers in this assay, from the lowest: compounds 2, 4, 1 and 3 (each within the scatter of the next, the first and the last beyond it).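

On a carbonyl carbon, isopropyl gives a 1.7-fold lower number from compound 3 to compound 4 (0.24 log units; within the scatter) in this assay when it takes the place of cyclopentylmethyl, so the ring can go without a step beyond the scatter. The same group gives a 1.2-fold higher number from compound 2 to compound 4 (0.07 log units; within the scatter) when it replaces propyl and a 1.3-fold lower number from compound 1 to compound 4 (0.10 log units; within the scatter) when it replaces isobutyl, and both of these also stay within the scatter. Among these four compounds the only step beyond the scatter remains a 2.1-fold higher number from compound 2 to compound 3 (0.31 log units; beyond the scatter) and it is modest, so straight, branched and ring-bearing carbon groups have so far moved the number little at this place.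

On these data alone, it remains open whether an amine, a hydroxyl-bearing chain or a chain longer than cyclopentylmethyl on this carbonyl carbon would move the number beyond the scatter. Nothing given here explains why these carbon groups give such close numbers.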